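From methyl to methoxy on a shared core

The compounds below may be only part of what the source reports. "The series", "measured", "known", "first", "only" and "open" are said of these compounds alone.

compound 1 `C=C(Br)C(=O)Nc1ccc(/C=C/C(=O)c2ccc(Br)cc2)cc1`: 620 nM
compound 2 `C=C(Br)C(=O)Nc1ccc(/C=C/C(=O)c2ccc(I)cc2)cc1`: 3400 nM
compound 3 `C=C(Br)C(=O)Nc1ccc(/C=C/C(=O)c2ccc(C)cc2)cc1`: 1900 nM

In a functional assay on L1210 cells (Mus musculus) for antiproliferative activity, with a stated time of 48 h (a higher number here means a weaker inhibitor, a lower number a stronger inhibitor), compound 3 gives 1900 nM. It cannot be told apart from compound 2, the step being a 1.8-fold lower number from compound 2 to compound 3 (0.25 log units; within the scatter). Compound 1 stands clear of it, with a 3.1-fold higher number from compound 1 to compound 3 (0.49 log units; beyond the scatter).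

Compound 4 `C=C(Br)C(=O)Nc1ccc(/C=C/C(=O)c2ccc(OC)cc2)cc1` differs from compound 3 by one change: methoxy in place of methyl on an aromatic carbon. Among the compounds with values here, no measured step makes this exchange. The closest evidence is the set of exchanges on that same aromatic carbon. Iodo in place of bromo gave a 5.5-fold higher number from compound 1 to compound 2 (0.74 log units; beyond the scatter), a modest step, and the methyl step from compound 1 was also modest. Within the data shown here, only the step leaving compound 1 exceeds the scatter, so these three compounds give no firm direction for the new exchange. The expected change is small, within the scatter: a 1.3-fold lower number from compound 3 to compound 4 (0.10 log units; within the scatter). The estimate for compound 4 is 1500 nM, with an expected range from 600 nM to 3800 nM.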

Compound 4, half-maximal inhibitory concentration: 980 nM
For compound 4 the middle estimate is 1.5-fold (0.18 log units) above the measured one; low and high end bracket the measured number.
By their numbers in this assay, from the lowest: compounds 1, 4, 3 and 2 (each within the scatter of the next, the first and the last beyond it).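

In this assay, within the data shown here, the methoxy exchange gives a step within the scatter, a 1.9-fold lower number from compound 3 to compound 4 (0.29 log units; within the scatter), and the exchange for bromo is also within it, a 1.6-fold higher number from compound 1 to compound 4 (0.20 log units; within the scatter), so compound 4 is the first compound here that cannot be told apart from either compound 1 or compound 3, although those two stand clear of each other. On this aromatic carbon, methoxy is separated only from iodo, in a modest step, a 3.5-fold lower number from compound 2 to compound 4 (0.54 log units; beyond the scatter). Nothing measured on these compounds accounts for the pattern.

The compounds shown leave open what an amine, a carboxylic acid or a longer chain such as ethoxy would do on this same aromatic carbon. They also leave open whether the methoxy exchange would read the same on any core other than the shared one.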